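Ring Size Change on a Sulfonamide and Lipophilicity

A few compounds are considered here, and "the series" means these few. Any claim that something is new, unique, unknown or untested is made for them only; others in the source may bear on it.

Measured compounds:
Compound 1, `O=S(=O)(c1cc(C(F)(F)F)ccc1Cl)N1CCCC1`, gives 3.44.
Compound 2, `O=S(=O)(c1cc(C(F)(F)F)ccc1Cl)N1CCCCC1`, gives 4.01.
Compound 3, `O=S(=O)(c1cc(C(F)(F)F)ccc1F)N1CCCC1`, gives 2.9.

All three were measured in a physicochemical assay for lipophilicity; on this read-out lower numbers stand for lower lipophilicity and higher numbers for higher lipophilicity. Compound 1 and compound 2 share one core and differ only in the ring bound to the sulfonyl sulfur: piperidin-1-yl in place of pyrrolidin-1-yl on a sulfonyl sulfur. This change gave a number 0.57 log units higher from compound 1 to compound 2 (beyond the scatter). Compound 3 carries a different core, and that difference is counted as fluoro in place of chloro on an aromatic carbon, with a number 0.54 log units lower from compound 1 to compound 3 (beyond the scatter). Compound 3 therefore stands lowest of the three measured compounds in this assay.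

Compound 4, `O=S(=O)(c1cc(C(F)(F)F)ccc1F)N1CCCCC1`, has not yet been measured. It differs from compound 3 by piperidin-1-yl in place of pyrrolidin-1-yl on a sulfonyl sulfur. The place of this change is described in exactly the same words as for the change from compound 1 to compound 2, so it is the same change made on the core of compound 3 instead of the core of compound 1. Among the compounds shown, the change from pyrrolidin-1-yl to piperidin-1-yl on a sulfonyl sulfur occurs twice in all, once measured and once not.

For the measured compounds named here, on that basis the step from compound 3 to compound 4 is expected to be about a number 0.57 log units higher from compound 3 to compound 4 (beyond the scatter), close to the measured step of a number 0.57 log units higher from compound 1 to compound 2 (beyond the scatter), because the single measured example of this change, a number 0.57 log units higher from compound 1 to compound 2 (beyond the scatter), is the only guide to its size. Compound 4 is therefore estimated at 3.47 in this assay, with an expected range from 3.2 to 3.75. This rests on one pair of measured compounds only, so the estimate remains tentative.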

Compound 4, partition coefficient: 3.47
The estimate for compound 4 equals the measured number at the digits printed, within the range that was stated.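

In this assay the ring change gave a number 0.57 log units higher from compound 3 to compound 4 (beyond the scatter), the same size at the printed digits as a number 0.57 log units higher from compound 1 to compound 2 (beyond the scatter), so within these two pairs it carried over from the core of compound 1 to the core of compound 3 with no visible loss or gain. The halogen change agrees with this picture: it gave a number 0.54 log units lower from compound 2 to compound 4 (beyond the scatter), which matches a number 0.54 log units lower from compound 1 to compound 3 (beyond the scatter), so in these four compounds the two changes simply add up, each keeping its size whichever form of the other is present. For the compounds shown here, this does not show that the ring change would have the same size on every core, as it rests on only two cores and one read-out, and nothing measured here explains why the size stayed the same.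

The compounds shown leave open whether other groups on the sulfonyl sulfur, such as morpholin-4-yl, azepan-1-yl or an open-chain diethylamino group, would continue the same trend. They also leave open whether the steps would keep their size with a bromo or methoxy group in place of the halogen, or on a core with a nitrile in place of the trifluoromethyl group.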